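Swapping an ester group for chloro

The compounds below may be only part of what the source reports. "The series", "measured", "known", "first", "only" and "open" are said of these compounds alone.

In a functional assay on A549 cells (Homo sapiens) for cytotoxicity, with a stated time of 48 h (on this read-out higher numbers stand for weaker inhibition and lower numbers for stronger inhibition), compound 2 (`CCCC(=O)Oc1ccc2oc(/C=C/[S+](C)[O-])cc(=O)c2c1`) gives 2200 nM and lies within the usual scatter of both other measured compounds. Compound 1 (`Cc1ccc2c(=O)cc(/C=C/[S+](C)[O-])oc2c1`) gives 2000 nM and compound 3 (`COc1cccc2oc(/C=C/[S+](C)[O-])cc(=O)c12`) gives 3800 nM with other groups on the shared core, so all three read alike. Compound 4 (`C[S+]([O-])/C=C/c1cc(=O)c2cc(Cl)ccc2o1`) is not yet measured and has chloro in place of (propylcarbonyl)oxy on an aromatic carbon. Among the compounds with values here, no two measured compounds differ in one place only, so no direct precedent exists for this change. Given how closely those three values agree, no step beyond the scatter is expected in this assay in either direction. Compound 4 is estimated at 2000 nM with a range of 900 nM to 4500 nM as the expected span. The estimated step (a 1.1-fold lower number from compound 2 to compound 4 (0.04 log units; within the scatter)) stays inside the scatter.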

Compound 4, half-maximal inhibitory concentration: 1700 nM
Beside the measured number, compound 4's estimate is 1.2-fold (0.07 log units) above it, and the stated range covers the measured number.
By their numbers in this assay, from the lowest: compounds 4, 1, 2 and 3 (each within the scatter of the next, the first and the last beyond it).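

Within the data shown here, this is the first direct comparison at this position: in this assay, chloro in place of (propylcarbonyl)oxy on an aromatic carbon gives a 1.3-fold lower number from compound 2 to compound 4 (0.11 log units; within the scatter). The much larger ester group, with its hydrogen-bond acceptors, can therefore give way to a single chlorine atom without a step beyond the scatter. Nothing available explains why the read-out stays so flat at this position. Still open, from the compounds shown here alone, is whether an amine, a carboxylic acid or a longer alkyl chain at the same place would shift the number beyond the scatter.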